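This account rests on a few compounds, and the source may have more. Where it says the series, first, only, none or still open, it means among the compounds named here.

Measured in a physicochemical assay for lipophilicity, read by HPLC, using the shake flask method; a lower number here means a more polar compound, a higher number a more lipophilic compound:
compound 1 `CCC/C(=N\C#N)N(C)Cc1ccc(Cl)nc1` gives 1.55
compound 2 `C/C(=N\C#N)N(Cc1ccc(Cl)nc1)C(C)C` gives 1.46

Compound 1 stands highest of the two numbers, and its nearest neighbour is compound 2, whose value lies only a little lower, a gap within the usual scatter of repeated measurements, so the two are not separated by this assay. The unmeasured compound 3 `CCCC/C(=N\C#N)N(C)Cc1ccc(Cl)nc1` differs from compound 1 in one place: methyl in place of hydrogen on a saturated chain carbon, three bonds along the chain from a carbon with a double bond to nitrogen. For the measured compounds named here, no step between measured compounds of this kind has been measured, so the size and direction of the change cannot be read off and must be expected. For compound 3 the expected step in this assay is a number 0.45 log units higher from compound 1 to compound 3 (beyond the scatter), a rise that should be beyond the scatter. The estimate for compound 3 in this assay is therefore 2, with a likely range from 1.7 to 2.3.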

Compound 3, partition coefficient: 1.87
Estimate against measurement, compound 3: 0.13 log units above, and the stated range covers the measured number.
By their numbers in this assay, from the lowest: compounds 2 and 1 (each within the scatter of the next); then compound 3.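

Going from propyl to butyl, that is, methyl in place of hydrogen on a saturated chain carbon, three bonds along the chain from a carbon with a double bond to nitrogen, gives in this assay a number 0.32 log units higher from compound 1 to compound 3 (beyond the scatter) and is the first step of any kind that can be read in this series. For the compounds shown here, it shows that a single added carbon at this place on the chain moves the number upward by a modest but real amount, which the earlier compounds, differing from each other in more than one place, could not show. Nothing at hand offers a reason for this step.

From the compounds shown here alone, whether the rise continues with a longer chain such as pentyl stays open, as a single step sets no trend. Going by these compounds, what a hydroxyl or an amine at this same place would do to the number also remains unknown.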